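This account rests on a few compounds, and the source may have more. Where it says the series, first, only, none or still open, it means among the compounds named here.

Working notes on the series. Compound 1 `CS(=O)(=O)OC1CCC(CN2CCN(c3cc(=O)c4cc(C(F)(F)F)cc([N+](=O)[O-])c4s3)CC2)CC1` is the reference point in an ADME assay on Vero cells (Chlorocebus sabaeus) for cytotoxicity, read by MTT assay, with a stated time of 48 h; on this read-out higher numbers stand for weaker inhibition and lower numbers for stronger inhibition. In this assay compound 1 gives > 64 ug/mL, which is a limit of the assay and not a number. Compound 2 `CC(C)S(=O)(=O)OC1CCC(CN2CCN(c3cc(=O)c4cc(C(F)(F)F)cc([N+](=O)[O-])c4s3)CC2)CC1` gives > 64 ug/mL in this assay, again a limit. Compound 3 `O=C(OC1CCC(CN2CCN(c3cc(=O)c4cc(C(F)(F)F)cc([N+](=O)[O-])c4s3)CC2)CC1)C1CCC1` gives > 64 ug/mL in this assay, also a limit. The measured steps are therefore all unreadable: a step that the two limits leave unreadable from compound 1 to compound 2, a step that the two limits leave unreadable from compound 1 to compound 3 and a step that the two limits leave unreadable from compound 2 to compound 3. What the three values share is the limit of > 64 ug/mL in this assay, at which 3 of the 3 values shown sit.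

The next compound is compound 4 `O=C(OC1CCC(CN2CCN(c3cc(=O)c4cc(C(F)(F)F)cc([N+](=O)[O-])c4s3)CC2)CC1)C1CCCCC1`, which differs from compound 1 as follows: cyclohexylcarbonyl in place of methylsulfonyl on an oxygen on a saturated carbon. Among the compounds with values here, the step that bears on this change most directly is the one from compound 1 to compound 3, where a cyclobutylcarbonyl replaced the methylsulfonyl on the same oxygen, and that step is unreadable because both values sit at the limit of > 64 ug/mL in this assay, at which 3 of the 3 values shown sit. Within the data shown here, no step in the set shows a readable size in this assay, so no step beyond the scatter is expected for compound 4; the estimated step is a step that the limit leaves unreadable from compound 1 to compound 4. Compound 4 is expected to give 100 ug/mL in this assay, with a range of 48 ug/mL to 300 ug/mL, most likely reported again as a limit.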

Compound 4, half-maximal inhibitory concentration: > 64 ug/mL
Compound 4: only a limit was reported (the forecaster's own chance of this, stated with the estimate: 85%); the middle value lies beyond the limit too.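

In this assay compound 4 gives > 64 ug/mL, which is a limit of the assay. Its steps from compound 1, compound 2 and compound 3 cannot be read, as all four values share one limit: the limit of > 64 ug/mL in this assay, at which 4 of the 4 values shown sit.

The compounds shown leave open where each true value lies beyond that limit, and whether any of these groups on the oxygen changes the result in this assay.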